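Chain length and cytotoxicity in one ester series

The source may hold more compounds than are shown below. What is called first, only, known or untested is meant among the compounds shown, and "the series" means these compounds.

Measured so far:
compound 1, `CCCCCCCCCCCOC(=O)CCC(=O)N1CCN(CCCOc2cc3c(Nc4ccc(F)c(Cl)c4)ncnc3cc2OC)CC1`, 12%
compound 2, `CCCCCCCCCCCCOC(=O)CCC(=O)N1CCN(CCCOc2cc3c(Nc4ccc(F)c(Cl)c4)ncnc3cc2OC)CC1`, 5.7%
compound 3, `CCCCCCCCCCCCCCCCCOC(=O)CCC(=O)N1CCN(CCCOc2cc3c(Nc4ccc(F)c(Cl)c4)ncnc3cc2OC)CC1`, 85.2%

In a functional assay on A549 cells (Homo sapiens) for cytotoxicity, read by MTT assay, with a stated time of 24 h, tested at 40 uM (on this read-out higher numbers stand for a weaker effect at the one concentration tested and lower numbers for a stronger effect), compound 3 stands highest of the three numbers, with 85.2%. Its nearest neighbour is compound 1, and the step of a number 73.2 percentage points higher from compound 1 to compound 3 (beyond the scatter) is large; the step of a number 79.5 percentage points higher from compound 2 to compound 3 (beyond the scatter) is larger still. Between compound 1 and compound 2 the step of a number 6.3 percentage points lower from compound 1 to compound 2 (within the scatter) lies within the scatter.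

Compound 4 is `CCCCCCCCCCCCCCCCCCCOC(=O)CCC(=O)N1CCN(CCCOc2cc3c(Nc4ccc(F)c(Cl)c4)ncnc3cc2OC)CC1`. It differs from compound 3 by ethyl in place of hydrogen on a saturated chain carbon, ten or more bonds along the chain from an oxygen next to a carbonyl group. Among the measured compounds shown here, the steps that bear on this change are those that also lengthen the chain at the same place: a number 73.2 percentage points higher from compound 1 to compound 3 (beyond the scatter) and a number 79.5 percentage points higher from compound 2 to compound 3 (beyond the scatter), both large and both upward, and a number 6.3 percentage points lower from compound 1 to compound 2 (within the scatter), which did not move beyond the scatter. Compound 3 already sits near the top of what this read-out can show, so the room left for a further rise is small. The account therefore expects for compound 4 a step of a number 2.8 percentage points higher from compound 3 to compound 4 (within the scatter) in this assay, upward if anything and probably not beyond the scatter. Compound 4 is estimated at 88%, with a range from 70% to 100%.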

Compound 4, a percentage reported as activity, at one concentration (the size of the read-out at that concentration, not a potency): 92.3%
Compound 4: the middle estimate sits 4.3 percentage points below what was measured, and the stated range covers the measured number.
By their numbers in this assay, from the lowest: compounds 2 and 1 (each within the scatter of the next); then compounds 3 and 4 (each within the scatter of the next).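

In this assay the step of a number 7.1 percentage points higher from compound 3 to compound 4 (within the scatter) shows that ethyl in place of hydrogen on a saturated chain carbon brings no change beyond the scatter, so the large rise seen earlier is not followed by a second one. The longer-chain end of the series is now held by two compounds rather than one: the steps of a number 86.6 percentage points higher from compound 2 to compound 4 (beyond the scatter) and a number 80.3 percentage points higher from compound 1 to compound 4 (beyond the scatter) are both large, and the four compounds fall into two pairs, compounds 1 and 2 at the low end and compounds 3 and 4 at the high end, with no compound shown standing in the gap. Nothing at hand explains why lengthening the chain separates these two pairs.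

The compounds shown leave open where along the chain, between the lengths of compound 2 and compound 3, the change sets in, and whether a longer chain would stay with compounds 3 and 4. They also leave open how a chain ending in an amine or a carboxylic acid would read at this place.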